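This account rests on a few compounds, and the source may have more. Where it says the series, first, only, none or still open, it means among the compounds named here.

Compound 1 `COc1cc(-c2nn(-c3cccc(NC(=O)Nc4cc(C(F)(F)F)cc(C(F)(F)F)c4)c3)cc2-c2ccncc2)ccc1Cl` is the stronger of the two compounds measured in a functional assay on RXF 393 cells (Homo sapiens) for inhibition, read by sulforhodamine B assay, with a stated time of 48 h; a higher number here means a weaker inhibitor of growth, a lower number a stronger inhibitor of growth: compound 1 gives 2060 nM, while compound 2 `O=C(Nc1cccc(-n2cc(-c3ccncc3)c(-c3ccc(Cl)c(O)c3)n2)c1)Nc1ccc(Cl)c(Cl)c1` gives 6400 nM, a gap beyond the usual scatter. Compound 3 `COc1cc(-c2nn(-c3cccc(NC(=O)Nc4cccc(C(F)(F)F)c4)c3)cc2-c2ccncc2)ccc1Cl` has not been measured. It differs from compound 1 in one place: hydrogen in place of trifluoromethyl on an aromatic carbon, on a six-membered aromatic ring of carbon only that still carries one other trifluoromethyl group. Within the data shown here, no pair of measured compounds shows this change, so nothing here tells how large its effect is. Taking away one of two trifluoromethyl groups is a modest change, and a small weakening is expected. The step from compound 1 to compound 3 is expected to be a 1.7-fold higher number from compound 1 to compound 3 (0.23 log units; within the scatter), a rise somewhat beyond the scatter. Compound 3 is estimated at 3500 nM, within a range from 1500 nM to 9000 nM.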

Compound 3, concentration for total growth inhibition: 1940 nM
Beside the measured number, compound 3's estimate is 1.8-fold (0.26 log units) above it, within the range that was stated.
By their numbers in this assay, from the lowest: compounds 3 and 1 (each within the scatter of the next); then compound 2.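

In this assay, taking away one of the two trifluoromethyl groups gives a 1.1-fold lower number from compound 1 to compound 3 (0.03 log units; within the scatter), so at this position on the ring, hydrogen and trifluoromethyl give numbers that cannot be told apart. Among these compounds, this is the first measured pair that differs in one place, and it shows that, in this assay, losing these four heavy atoms leaves the number within the scatter of the value for compound 1. Nothing available here explains why so large a change in atoms leaves the number within the scatter. Still open, from the compounds shown here alone, is what happens to the number if the remaining trifluoromethyl group is replaced by hydrogen as well. Also open, going by these compounds, is whether a different group at the emptied position, such as an amine or a carboxylic acid, would move the number beyond the scatter.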